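Moving a methyl on the alkyne-linked phenyl ring

The source may hold more compounds than are shown below. What is called first, only, known or untested is meant among the compounds shown, and "the series" means these compounds.

Compound 1 `CNC(=O)c1ccc(C#Cc2ccccc2)nc1` — 15000 nM
Compound 2 `CC(C)NC(=O)c1ccc(C#Cc2ccccc2)nc1` — 7100 nM
Compound 3 `Cc1ccccc1C#Cc1ccc2c(n1)CCN(C)C2=O` — > 32000 nM

All three were tested in an assay on HEK293 cells for displacement of a labelled ligand from metabotropic glutamate receptor 5 (Homo sapiens), with a stated time of 2 h; a lower number here means a stronger inhibitor, a higher number a weaker inhibitor. Among the measured compounds shown here, compound 1 and compound 2 share an open amide on a pyridine bearing a phenyl alkyne, and the step of a 2.1-fold lower number from compound 1 to compound 2 (0.32 log units; beyond the scatter) is the only measured comparison available. Compound 3 is built differently: its amide is folded into a bicyclic core, and the phenyl on the alkyne carries a methyl. On these data alone, for compound 3 this assay reports only a limit, > 32000 nM, not a number; it is the weakest-looking entry on the sheet, though how far beyond the limit it lies is unknown (the limit of > 32000 nM in this assay, at which 1 of the 3 values shown sits).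

Compound 4 `Cc1cccc(C#Cc2ccc3c(n2)CCN(C)C3=O)c1` keeps the core of compound 3 and differs only in where the methyl sits on the phenyl ring: 3-methylphenyl in place of 2-methylphenyl on a triple-bonded carbon. For the measured compounds named here, no measured step touches that ring; the single known step, between compound 1 and compound 2, changes the group on the amide nitrogen instead, so it gives no guide to the size or direction of this change. The expectation therefore rests on little. Compound 4 is estimated at 3000 nM (range 300 nM to 32000 nM), which would mean an expected step of an at least 10-fold lower number from compound 3 to compound 4 (1.02 log units; beyond the scatter), with a real chance that this assay again returns only a limit.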

Compound 4, inhibition constant: 820 nM
Beside the measured number, compound 4's estimate is 3.7-fold (0.56 log units) above it, within the range that was stated.
By their numbers in this assay, from the lowest: compound 4; then compound 2; then compound 1. At a limit, above all of these: compound 3.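

In this assay, moving one methyl group gives an at least 39-fold lower number from compound 3 to compound 4 (1.59 log units; beyond the scatter), which shows that the place of the methyl on the ring attached to the triple-bonded carbon matters. The earlier step could not show this, as it changed only the group on the amide nitrogen. 2-Methylphenyl and 3-methylphenyl also match in every count computed for them, so those counts do not separate the two compounds, and the true size of the step stays unknown, since compound 3 stands at a limit and not at a number: the limit of > 32000 nM in this assay, at which 1 of the 4 values shown sits.

The compounds shown leave open whether a chlorine or a methoxy group in place of the methyl of 3-methylphenyl would keep, lower or raise the number seen for compound 4. Among the compounds shown here, they also leave open whether 3-methylphenyl would lower the number on the open amide of compound 2, and how much of the standing of compound 4 belongs to its core, for compound 4 differs from compound 1 and compound 2 in more than one place and no step links them.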